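Aryl versus pyrazole on the ether side chain

A few compounds are considered here, and "the series" means these few. Any claim that something is new, unique, unknown or untested is made for them only; others in the source may bear on it.

Measured compounds:
compound 1 `Cc1nn(-c2ncnc3nc[nH]c23)c2c1C(OCC(=O)c1ccc(F)cc1)CC(=O)N2` — 3 nM
compound 2 `Cc1nn(-c2ncnc3nc[nH]c23)c2c1C(OCCn1cccn1)CC(=O)N2` — 16 nM

For the measured compounds named here, in a functional assay on HEK293 cells for agonist activity at G-protein coupled receptor 39 (Homo sapiens), read by scintillation proximity assay and inositol phosphate accumulation, with a stated time of 75 min, in the presence of a further agent that is not named here (on this read-out higher numbers stand for an effect only at larger amounts of compound and lower numbers for an effect already at smaller amounts), compound 2 stands highest of the two numbers; the nearest is compound 1, which gives 3 nM, and the one measured step is a 5.3-fold higher number from compound 1 to compound 2 (0.73 log units; beyond the scatter). Compound 3 `COc1ccc(CCOC2CC(=O)Nc3c2c(C)nn3-c2ncnc3nc[nH]c23)cc1` differs from compound 2 by 4-methoxyphenyl in place of 1H-pyrazol-1-yl on a saturated chain carbon, two bonds along the chain from an oxygen on a saturated carbon. Going by the values given here, no measured pair carries exactly this change; the step from compound 1 to compound 2 is the only one that bears on it, and it shows an aromatic six-membered ring of carbon giving the lower number. A modest step down is therefore expected, a 2.0-fold lower number from compound 2 to compound 3 (0.30 log units; within the scatter). Compound 3 is estimated at 8 nM in this assay, with a range of 2 nM to 30 nM.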

Compound 3, half-maximal effective concentration: 2 nM
For compound 3 the middle estimate is 4.0-fold (0.60 log units) above the measured one, within the range that was stated.
By their numbers in this assay, from the lowest: compounds 3 and 1 (each within the scatter of the next); then compound 2.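

In this assay, 4-methoxyphenyl in place of 1H-pyrazol-1-yl gives an 8.0-fold lower number from compound 2 to compound 3 (0.90 log units; beyond the scatter), so at this position the ring carbon-only aromatic side chain reads clearly lower even without a carbonyl in the chain. The other single-place comparison gives a 1.5-fold lower number from compound 1 to compound 3 (0.18 log units; within the scatter), so the two aryl side chains cannot be separated, although only compound 1 carries the carbonyl. No supporting data bear on why either step takes this size.

As far as these compounds go, what the methoxy group itself contributes remains open. So does the reading of a ring bearing an amine or a carboxylic acid, or of a longer chain.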